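Chloro added to compound 2: expected step

The source may report more compounds than this note shows. Statements on the series, on what has been measured and on what is new or still open speak of the compounds shown alone.

In a functional assay on P388 cells (Mus musculus) for antiproliferative activity, read by colorimetric assay and MTT assay (on this read-out higher numbers stand for weaker inhibition and lower numbers for stronger inhibition), compound 1 (`COc1ccc(S(=O)(=O)Nc2cccc3cc[nH]c23)cc1`) gives 1.1 ug/mL, and compound 2 (`O=[N+]([O-])c1ccc(S(=O)(=O)Nc2cccc3cc[nH]c23)cc1`) gives 8.2 ug/mL, the higher of the two numbers. Compound 3 (`O=[N+]([O-])c1ccc(S(=O)(=O)Nc2cccc3cc(Cl)[nH]c23)cc1`) has chloro in place of hydrogen on an aromatic carbon of the five-membered ring, next to the ring nitrogen: chloro in place of hydrogen on an aromatic carbon. Among the compounds with values here, the only measured step, a 7.5-fold higher number from compound 1 to compound 2 (0.87 log units; beyond the scatter), is nitro in place of methoxy at another place, so it shows a modest size but no direction for this change. A small move towards a lower number is tentatively expected, a 2.1-fold lower number from compound 2 to compound 3 (0.31 log units; beyond the scatter). Compound 3 is estimated at 4 ug/mL, within a range of 1 ug/mL to 14 ug/mL.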

Compound 3, half-maximal inhibitory concentration: 21 ug/mL
Estimate against measurement, compound 3: 5.3-fold (0.72 log units) below, and the stated range ends below it.
By their numbers in this assay, from the lowest: compound 1; then compound 2; then compound 3.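

In this assay, chloro in place of hydrogen on an aromatic carbon of a five-membered aromatic ring, next to the ring nitrogen, gives a 2.6-fold higher number from compound 2 to compound 3 (0.41 log units; beyond the scatter) and so gives this change a direction, towards weaker inhibition. The step is modest and rests on one pair, with nitro on the other ring. No available data account for this direction.

From the compounds shown here alone, whether chloro moves the number the same way alongside the methoxy group of compound 1 remains open. Also open, going by these compounds, is how a methyl, an amine or a carboxylic acid on this carbon would compare with chloro.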